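Amide-nitrogen variation in a stilbene-cinnamamide series

The source may report more compounds than this note shows. Statements on the series, on what has been measured and on what is new or still open speak of the compounds shown alone.

Among the compounds with values here, the three measured members share one core and differ only at the amide nitrogen. Compound 1 `CCC(C)NC(=O)/C=C/c1c(/C=C/c2ccc(OC)cc2)cc(OC)cc1OC` gives 3950 nM in a functional assay on A549 cells (Homo sapiens) for inhibition, read by MTT assay, with a stated time of 48 h; on this read-out higher numbers stand for weaker inhibition and lower numbers for stronger inhibition. Compound 2 `COc1ccc(/C=C/c2cc(OC)cc(OC)c2/C=C/C(=O)Nc2cc(OC)c(OC)c(OC)c2)cc1` gives 5140 nM in this assay, and compound 3 `COc1ccc(/C=C/c2cc(OC)cc(OC)c2/C=C/C(=O)NC2CC2)cc1` gives 8810 nM in this assay. Compound 3 holds the highest of the three numbers: a 1.7-fold higher number from compound 2 to compound 3 (0.23 log units; within the scatter), and a 2.2-fold higher number from compound 1 to compound 3 (0.35 log units; beyond the scatter).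

Compound 4 `COc1ccc(/C=C/c2cc(OC)cc(OC)c2/C=C/C(=O)N2CCN(C)CC2)cc1` is not yet measured. Its change from compound 3 is 4-methylpiperazin-1-yl in place of cyclopropylamino on a carbonyl carbon. The cyclopropylamino that leaves carries 1 hydrogen-bond donor; the 4-methylpiperazin-1-yl that enters carries none and brings one six-membered non-aromatic ring with 2 hetero atoms.

Every measured step touches the same position: a 1.3-fold higher number from compound 1 to compound 2 (0.11 log units; within the scatter), a 2.2-fold higher number from compound 1 to compound 3 (0.35 log units; beyond the scatter), a 1.7-fold higher number from compound 2 to compound 3 (0.23 log units; within the scatter). Across sec-butyl, 3,4,5-trimethoxyphenyl and cyclopropyl the numbers stay close, which points to a position that tolerates change. Within the data shown here, no measured compound lacks the amide hydrogen, so that part of the change is untested. Compound 4 is therefore expected to fall near compound 3, with a step of a 1.3-fold lower number from compound 3 to compound 4 (0.10 log units; within the scatter) and no movement beyond the scatter firmly predicted. The estimate for compound 4 in this assay is 7000 nM, within 2500 nM to 20000 nM.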

Compound 4, half-maximal inhibitory concentration: 4510 nM
The estimate for compound 4 lay 1.6-fold (0.19 log units) above the measured number; the measured number falls inside the stated range.
By their numbers in this assay, from the lowest: compounds 1, 4, 2 and 3 (each within the scatter of the next, the first and the last beyond it).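

Compound 4 is the only member shown without the amide hydrogen, and in this assay that loss, together with the entry of the 4-methylpiperazin-1-yl ring on the carbonyl carbon, gives a 2.0-fold lower number from compound 3 to compound 4 (0.29 log units; within the scatter) and, against the sec-butyl amide, a 1.1-fold higher number from compound 1 to compound 4 (0.06 log units; within the scatter). Neither step lies beyond the scatter, so among the compounds shown, the amide hydrogen is not needed for a number in the same region as those of compound 1 and compound 3, and a six-membered ring with 2 hetero atoms is accepted in this place. Nothing available on the series bears on why the numbers stay this close.

The hydrogen and the ring change together here, so their separate contributions remain unresolved; a dimethylamino group on the same carbonyl carbon, with no amide hydrogen and no ring, or a morpholin-4-yl group, with a ring oxygen in place of the methylated nitrogen, would pull these apart. On these data alone, a carboxylic acid or a primary amine carried on a longer chain from the amide nitrogen also remains open, as does whether this tolerance holds on any other core.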